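The compounds below may be only part of what the source reports. "The series", "measured", "known", "first", "only" and "open" are said of these compounds alone.

In a functional assay on RPMI-8226 cells (Homo sapiens) for inhibition, read by sulforhodamine B assay, with a stated time of 48 h (on this read-out higher numbers stand for weaker inhibition of growth and lower numbers for stronger inhibition of growth), compound 1 (`COc1cc(-c2nn(-c3cccc(NC(=O)Nc4ccc(Cl)c(Cl)c4)c3)cc2-c2ccncc2)ccc1Cl`) gives 388 nM and compound 2 (`COc1cc(-c2nn(-c3cccc(NC(=O)Nc4cccc(C(F)(F)F)c4)c3)cc2-c2ccncc2)ccc1Cl`) gives 340 nM, and the two are separated by a 1.1-fold lower number from compound 1 to compound 2 (0.06 log units; within the scatter). Compound 3 (`COc1cc(-c2nn(-c3cccc(NC(=O)c4ccc(Cl)c(C(F)(F)F)c4)c3)cc2-c2ccncc2)ccc1Cl`) gives 1620 nM, the highest number of the three and so the weakest growth inhibition among them, as a 4.2-fold higher number from compound 1 to compound 3 (0.62 log units; beyond the scatter) and a 4.8-fold higher number from compound 2 to compound 3 (0.68 log units; beyond the scatter) show.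

Compound 4 (`COc1cc(-c2nn(-c3cccc(NC(=O)c4ccccc4)c3)cc2-c2ccncc2)ccc1Cl`) differs from compound 3 on a carbonyl carbon, where phenyl stands in place of 4-chloro-3-(trifluoromethyl)phenyl: phenyl in place of 4-chloro-3-(trifluoromethyl)phenyl on a carbonyl carbon. Going by the values given here, no measured compound carries this unsubstituted phenyl, so no step tests the change directly. The step from 1 to 2 exchanges one substituted phenyl for another and never leaves the ring bare. The two steps to compound 3 instead replace an amino-linked aryl group on the carbonyl carbon with a directly attached one. They offer only a rough guide to size, and the direction remains a judgement. A modest move toward a higher number in this assay is expected, somewhat smaller than those two steps. The estimated change is a 2.2-fold higher number from compound 3 to compound 4 (0.33 log units; beyond the scatter). The expected value for compound 4 is 3500 nM, with an estimated range of 1300 nM to 10000 nM.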

Compound 4, concentration for 50% growth inhibition: 850 nM
For compound 4 the middle estimate is 4.1-fold (0.61 log units) above the measured one, and the stated range ends above it.
By their numbers in this assay, from the lowest: compounds 2 and 1 (each within the scatter of the next); then compounds 4 and 3 (each within the scatter of the next).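

In this assay, the 4-chloro and 3-trifluoromethyl substituents on the phenyl attached to the carbonyl carbon turn out to carry little weight, since removing both leaves the two compounds within the scatter of each other (a 1.9-fold lower number from compound 3 to compound 4 (0.28 log units; within the scatter)). Compound 4 still sits apart from the two compounds with an amino-linked aryl group on the carbonyl carbon (a 2.5-fold higher number from compound 2 to compound 4 (0.40 log units; beyond the scatter); a 2.2-fold higher number from compound 1 to compound 4 (0.34 log units; beyond the scatter)), so the modest gap seen earlier with the substituted ring is also present with the bare phenyl, although these steps also differ in the ring substituents and so do not isolate the amino link. Nothing available here accounts for why this ring tolerates the loss of its substituents.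

On these data alone, it remains open whether a single chlorine or a single trifluoromethyl on this phenyl would give a number in the same range as the bare ring and the doubly substituted one, and whether a bare phenylamino group on the carbonyl carbon would match the substituted ones. Also open, as far as these compounds go, is how a non-aromatic group on the carbonyl carbon, such as a piperidine or a short chain ending in a carboxylic acid, would compare with the phenyl.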